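Chloro to Nitro on the Aryl Sulfonate

This account rests on a few compounds, and the source may have more. Where it says the series, first, only, none or still open, it means among the compounds named here.

Compound 2, `CNC(=O)/C=C1/COc2cc(OS(=O)(=O)c3ccc(Cl)cc3)ccc21`, gives 6% in an assay (strain Sprague-Dawley) for inhibition of Amine oxidase [flavin-containing] B (Rattus norvegicus), read by spectrophotometry, with a stated time of 5 min, tested at 10 uM; on this read-out higher numbers stand for more inhibition at the one concentration tested (going by the name of the read-out) and lower numbers for less inhibition. Compound 1, `CNC(=O)/C=C1/COc2cc(OS(=O)(=O)c3ccccc3)ccc21`, gives 0% in this assay. Of the two numbers shown, compound 2 is the one nearest compound 1, and the gap between them is within the scatter, so the two are not separated by these data. Going by the values given here, the only measured step, a number 6 percentage points higher from compound 1 to compound 2 (within the scatter), came with chloro in place of hydrogen on an aromatic carbon.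

Compound 3, `CNC(=O)/C=C1/COc2cc(OS(=O)(=O)c3ccc([N+](=O)[O-])cc3)ccc21`, is not yet measured. It differs from compound 2 by nitro in place of chloro on an aromatic carbon. Among the compounds with values here, no measured step touches a nitro group, and the one known step, a number 6 percentage points higher from compound 1 to compound 2 (within the scatter), stayed within the scatter, so nothing here points to a step beyond the scatter in this assay. Compound 3 is therefore expected at 5%, with a range from -5% to 20%. This amounts to an expected a number 1 percentage points lower from compound 2 to compound 3 (within the scatter).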

Compound 3, a percentage reported as inhibition, at one concentration (the size of the read-out at that concentration, not a potency): 13%
Compound 3: the middle estimate sits 8 percentage points below what was measured, within the range that was stated.
By their numbers in this assay, from the lowest: compounds 1, 2 and 3 (each within the scatter of the next, the first and the last beyond it).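

In this assay, this position on the aryl sulfonate now gives its first step beyond the scatter, though a modest one: a number 13 percentage points higher from compound 1 to compound 3 (beyond the scatter). The change from chloro to nitro, by contrast, amounts to a number 7 percentage points higher from compound 2 to compound 3 (within the scatter), so these data do not separate the two groups, and only nitro stands apart from the unsubstituted hydrogen. Nothing available gives a reason for the difference between the hydrogen and nitro compounds.

On these data alone, what an amine or a carboxylic acid on this aromatic carbon would give remains open. Also open, as far as these compounds go, is how the three compounds would compare in potency, since each reading comes from a single concentration and says nothing about a full concentration response.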